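A Fluorine on the Benzotriazole Ring of Compound 2

The source may hold more compounds than are shown below. What is called first, only, known or untested is meant among the compounds shown, and "the series" means these compounds.

Of the compounds shown here, two have been measured in an assay on isolated protein for binding affinity to 5-hydroxytryptamine receptor 7 (Homo sapiens) (a higher number here means a weaker inhibitor, a lower number a stronger inhibitor), so far. Compound 1 `O=C1c2ccccc2CCCN1CCN1CCC(c2c[nH]c3ccccc23)CC1` gives 0.407 nM in this assay, and compound 2 `O=C1c2ccccc2CCCN1CCN1CCC(n2nnc3ccccc32)CC1` gives 14.1 nM. Among the measured compounds shown here, of these two numbers, compound 2 carries the higher one: the single measured step shows a 35-fold higher number from compound 1 to compound 2 (1.54 log units; beyond the scatter).

Compound 3 `O=C1c2ccccc2CCCN1CCN1CCC(n2nnc3cc(F)ccc32)CC1` is the next compound. It differs from compound 2 by fluoro in place of hydrogen on an aromatic carbon.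

For the measured compounds named here, no measured step speaks to this change. Going by the values given here, the only step available swaps one fused two-ring group for another, which is not comparable with adding a single fluorine to an aromatic carbon. With nothing to build on, the expectation is a step of a 1.0-fold lower number from compound 2 to compound 3 (0.00 log units; within the scatter), that is, no change beyond the scatter. Compound 3 is therefore estimated at 14 nM in this assay, with a range from 5 nM to 40 nM.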

Compound 3, inhibition constant: 2.04 nM
Compound 3: the middle estimate sits 6.9-fold (0.84 log units) above what was measured, outside the stated range (below it).
By their numbers in this assay, from the lowest: compound 1; then compound 3; then compound 2.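

In this assay, adding a single fluoro gives a 6.9-fold lower number from compound 2 to compound 3 (0.84 log units; beyond the scatter), so this aromatic carbon, meta to a fused ring and para to a fused ring, is a place where a one-atom change matters. Even so, the group carried by compound 3 does not fully close the gap to the group in compound 1, as the comparison shows a 5.0-fold higher number from compound 1 to compound 3 (0.70 log units; beyond the scatter). No measurement at hand says why the fluoro step has this size.

From the compounds shown here alone, it remains open whether chloro, methoxy or a nitrile on the same carbon would lower the number as fluoro does, and whether fluoro on another carbon of that ring would do the same. Also open, going by these compounds, is whether fluoro on the corresponding ring of compound 1 would bring a similar step.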